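The source may hold more compounds than are shown below. What is called first, only, known or untested is meant among the compounds shown, and "the series" means these compounds.

Compound 1 `OC[C@@]1(c2cccc(F)c2)NC[C@@H](O)[C@@H]1O` and compound 2 `OC[C@@]1(c2ccc(O)cc2)NC[C@@H](O)[C@@H]1O` share a core that carries a six-membered aromatic ring of carbon only. In an assay on isolated protein for inhibition of tissue alpha-L-fucosidase (Bos taurus), tested at 1000 uM (a lower number here means less inhibition, a higher number more inhibition at the concentration tested (going by the name of the read-out)), compound 1 gives 0%. In this assay compound 2 gives 0%, level with compound 1 at the digits shown and within the scatter, so no order between the two can be stated. Compound 3 `OC[C@@]1(c2ccccc2)NC[C@@H](O)[C@@H]1O` has not yet been measured in this assay. It differs from compound 2 in one place: hydrogen in place of hydroxy on an aromatic carbon. Among the measured compounds shown here, no step between measured compounds is available, since compound 1 and compound 2 differ in more than one place, so the data give no direct guide to what the loss of a hydroxy does on this core. Both measured compounds show no inhibition at the concentration tested. For that reason the step of no change at the digits printed from compound 2 to compound 3 (within the scatter) is expected to be none beyond the scatter. Compound 3 is estimated to give 0% in this assay, with a range from 0% to 10%.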

Compound 3, a percentage reported as inhibition, at one concentration (the size of the read-out at that concentration, not a potency): 0%
Compound 3: the middle estimate sits on the measured number at the digits printed; measured number inside the range.
By their numbers in this assay, from the lowest: compounds 1, 2 and 3 (each within the scatter of the next).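

In this assay, the change of hydroxy to hydrogen on the aromatic carbon gives no change at the digits printed from compound 2 to compound 3 (within the scatter), and the change of fluoro to hydrogen gives no change at the digits printed from compound 1 to compound 3 (within the scatter). The earlier compounds shown here could not show this, as they differed in more than one place; compound 3 now links each of them to a ring without either group, and neither group separates from hydrogen on this core, although all three compounds sit at the same reading of no inhibition, so these steps cannot show any smaller contribution from either group. Nothing available accounts for this result.

From the compounds shown here alone, it remains open whether an amine or a carboxylic acid on the aromatic ring would give any inhibition in this assay. Going by these compounds, it is equally open whether a longer chain between the core and the ring would do so.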